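Pyrrolidin-1-yl in place of 4-methylpiperazin-1-yl: working notes

A few compounds are considered here, and "the series" means these few. Any claim that something is new, unique, unknown or untested is made for them only; others in the source may bear on it.

Measured in a functional assay on A549 cells (Homo sapiens) for antiproliferative activity, read by MTT assay, with a stated time of 48 h; a lower number here means a stronger inhibitor, a higher number a weaker inhibitor:
- compound 1 `CN1CCN(CCCOc2c(OCc3ccccc3)cc3oc(-c4ccccc4)cc(=O)c3c2O)CC1`: 1300 nM
- compound 2 `CN1CCN(CCCCOc2c(OCc3ccccc3)cc3oc(-c4ccccc4)cc(=O)c3c2O)CC1`: 4400 nM

Of the two measured compounds, compound 2 holds the higher number, at 4400 nM. Compound 3 `O=c1cc(-c2ccccc2)oc2cc(OCc3ccccc3)c(OCCCCN3CCCC3)c(O)c12` is the unmeasured partner of compound 2: pyrrolidin-1-yl in place of 4-methylpiperazin-1-yl on a saturated chain carbon, four bonds along the chain from an oxygen on an aromatic ring.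

For the measured compounds named here, the only measured step, a 3.4-fold higher number from compound 1 to compound 2 (0.53 log units; beyond the scatter), is modest. It changes the chain and keeps 4-methylpiperazin-1-yl, so it offers only a rough scale, and no exchange of this ring has been measured. In this assay, the expected change is small, with a slight lean towards a lower number and nothing expected beyond the scatter: the estimated step is a 1.5-fold lower number from compound 2 to compound 3 (0.17 log units; within the scatter). Compound 3 is estimated at 3000 nM, with an expected range of 1000 nM to 9000 nM.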

Compound 3, half-maximal inhibitory concentration: 800 nM
The estimate for compound 3 lay 3.8-fold (0.57 log units) above the measured number, outside the stated range (below it).
By their numbers in this assay, from the lowest: compounds 3 and 1 (each within the scatter of the next); then compound 2.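

In this assay, exchanging the ring at the end of the chain gives a 5.5-fold lower number from compound 2 to compound 3 (0.74 log units; beyond the scatter) and so shows that the number at this position depends on the ring as well as the chain. The second comparison, a 1.6-fold lower number from compound 1 to compound 3 (0.21 log units; within the scatter) leaves these two compounds level, so the higher number of compound 2 is not shared by compound 3 on the same chain. No measurement at hand accounts for this exchange.

Open, as far as these compounds go, is how pyrrolidin-1-yl behaves on the chain of compound 1. Also open, from the compounds shown here alone, is whether piperidin-1-yl, morpholin-4-yl or a longer chain would follow the same course.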